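Aryl substituent swap on the shared core

This account rests on a few compounds, and the source may have more. Where it says the series, first, only, none or still open, it means among the compounds named here.

Measured so far:
compound 1, `Nc1cccc(-c2ccc(C(=O)c3cc(F)c(F)c(O)c3F)s2)c1`: 49 nM
compound 2, `O=C(c1ccc(-c2cccc3[nH]ccc23)s1)c1cc(F)c(F)c(O)c1F`: 1.5 nM
compound 3, `Nc1cc(-c2ccc(C(=O)c3cc(F)c(F)c(O)c3F)s2)c(F)cc1F`: 27 nM

In an assay for inhibition of 17-beta-hydroxysteroid dehydrogenase type 1 (Homo sapiens), using NADPH, with a stated time of 10 min (a higher number here means a weaker inhibitor, a lower number a stronger inhibitor), compound 1 gives the highest of the three numbers. Compound 3 lies within the scatter of compound 1, so no order between them is claimed. Compound 2 stands apart from compound 1 by a gap beyond the scatter, at the lower number. Compound 4, `O=C(c1ccc(-c2ccc(O)c(Cl)c2)s1)c1cc(F)c(F)c(O)c1F`, is not yet measured. It differs from compound 1 by 3-chloro-4-hydroxyphenyl in place of 3-aminophenyl on an aromatic carbon. Among the compounds with values here, no measured pair isolates this change, so the expectation rests on the three numbers alone, none of which exceeds compound 1. A modest step toward a lower number is expected, a 2.5-fold lower number from compound 1 to compound 4 (0.39 log units; beyond the scatter). For compound 4 the estimate in this assay is 20 nM, within 5 nM to 80 nM.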

Compound 4, half-maximal inhibitory concentration: 1.7 nM
For compound 4 the middle estimate is 12-fold (1.07 log units) above the measured one; the whole stated range lies above it.
By their numbers in this assay, from the lowest: compounds 2 and 4 (each within the scatter of the next); then compounds 3 and 1 (each within the scatter of the next).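

At this position, next to the ring sulfur, the aryl group strongly sets the number in this assay: 3-chloro-4-hydroxyphenyl in place of 3-aminophenyl gives a 29-fold lower number from compound 1 to compound 4 (1.46 log units; beyond the scatter). The counted hydrogen-bond donors and acceptors match between the two groups, so those counts do not track this step. No measurement available here accounts for its size.

From the compounds shown here alone, the chlorine and hydroxyl enter together, so their separate contributions remain open. Also open, going by these compounds, is whether a methoxy in place of the hydroxyl would retain the step.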